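From 4-methylphenyl to 3-chlorophenyl at the assay limit

The source may report more compounds than this note shows. Statements on the series, on what has been measured and on what is new or still open speak of the compounds shown alone.

In a functional assay on MCF7 cells (Homo sapiens) for cytotoxicity, read by sulforhodamine B assay (a higher number here means a weaker inhibitor of growth, a lower number a stronger inhibitor of growth), compound 1 `CC1=CC[C@@H]([C@@](C)(O)CCCC(C)(C)NC(=S)NN)CC1` gives 84200 nM. Compound 2 `CC1=CC[C@@H]([C@@](C)(O)CCCC(C)(C)NC(=S)N/N=C\c2ccc(C)cc2)CC1` reads > 100000 nM, which is a limit and not a number. Compound 3 `CC1=CC[C@@H]([C@@](C)(O)CCCC(C)(C)NC(=S)N/N=C\c2ccc([N+](=O)[O-])cc2)CC1` reads > 100000 nM, which is likewise a limit. Compound 2 therefore stands at the limit of > 100000 nM in this assay, at which 2 of the 3 values shown sit.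

Compound 4 `CC1=CC[C@@H]([C@@](C)(O)CCCC(C)(C)NC(=S)N/N=C\c2cccc(Cl)c2)CC1` differs from compound 2 in one place: 3-chlorophenyl in place of 4-methylphenyl on a carbon with a double bond to nitrogen. In words, 3-chlorophenyl stands in place of 4-methylphenyl on a carbon with a double bond to nitrogen.

Among the compounds with values here, two measured steps bear on this change. The first, an at least 1.1-fold higher number from compound 1 to compound 2 (0.07 log units; that floor lies within the scatter), gives only a floor. The second, a step that the two limits leave unreadable from compound 2 to compound 3, is the closer parallel, as it also changes a substituent on the aromatic ring, but its size cannot be read. Neither step gives a size for such a change, so no step beyond the scatter is expected in this assay. The expected change is an at least 1.0-fold lower number from compound 2 to compound 4 (0.02 log units; that floor lies within the scatter). For compound 4 the estimate is 95000 nM, with an expected range from 45000 nM to 140000 nM.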

Compound 4, concentration for total growth inhibition: 19500 nM
Compound 4: the middle estimate sits 4.9-fold (0.69 log units) above what was measured; the whole stated range lies above it.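

In this assay, the aryl group on a carbon with a double bond to nitrogen proves able to move the reading: 3-chlorophenyl gives an at least 5.1-fold lower number from compound 2 to compound 4 (0.70 log units; beyond the scatter) and an at least 5.1-fold lower number from compound 3 to compound 4 (0.70 log units; beyond the scatter) in this series, which the two earlier limits could not show. Against the core of compound 1, the whole added group now gives a 4.3-fold lower number from compound 1 to compound 4 (0.64 log units; beyond the scatter) as a sized step, whereas the 4-methylphenyl version gave only a floor within the scatter. Compound 2 reads as a limit and so does compound 3, and the first two steps are floors because they start from such a limit: the limit of > 100000 nM in this assay, at which 2 of the 4 values shown sit.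

On these data alone, it stays open whether the chlorine or the 3-position carries the step. A 4-chlorophenyl, 3-methylphenyl or 3-nitrophenyl group would separate the two.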